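Shifting the Pyridine Nitrogen from Compound 2 to Compound 3

The compounds below may be only part of what the source reports. "The series", "measured", "known", "first", "only" and "open" are said of these compounds alone.

Compound 1, `CN1C/C(=C\c2cccnc2)C(=O)/C(=C/c2ccccc2C(F)(F)F)C1`: in a functional assay on HepG2 cells (Homo sapiens) for cytotoxicity, read by MTT assay, with a stated time of 24 h (a lower number here means a stronger inhibitor, a higher number a weaker inhibitor), compound 1 gives 2550 nM.
Compound 2, `N#Cc1ccc(S(=O)(=O)N2C/C(=C\c3cccnc3)C(=O)/C(=C/c3ccccc3C(F)(F)F)C2)cc1`: in this assay compound 2 gives 5060 nM.
Compound 3, `N#Cc1ccc(S(=O)(=O)N2C/C(=C\c3ccncc3)C(=O)/C(=C/c3ccccc3C(F)(F)F)C2)cc1`: not yet measured in this assay.

Going by the values given here, compound 2 carries the highest of the two numbers measured so far in this assay; its nearest neighbour is compound 1, and the step of a 2.0-fold higher number from compound 1 to compound 2 (0.30 log units; within the scatter) lies within the scatter, so the two values cannot be ordered against each other. That single step exchanges the group on the amine nitrogen in the ring, which is a different place from where compound 3 departs from compound 2. Compound 3 differs from compound 2 in one respect only: pyridin-4-yl in place of pyridin-3-yl on a double-bonded chain carbon bound to a double-bonded ring carbon. Among the compounds with values here, no measured pair shows a change of this kind, so the measured compounds give no direction for it. The expectation for compound 3 is therefore a number close to that of compound 2, with the step of a 1.0-fold lower number from compound 2 to compound 3 (0.01 log units; within the scatter) expected to remain within the scatter. Compound 3 is estimated at 5000 nM in this assay, with a range from 2000 nM to 12500 nM.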

Compound 3, half-maximal inhibitory concentration: 5920 nM
Compound 3: the middle estimate sits 1.2-fold (0.07 log units) below what was measured, within the range that was stated.
By their numbers in this assay, from the lowest: compounds 1, 2 and 3 (each within the scatter of the next, the first and the last beyond it).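

In this assay, pyridin-4-yl in place of pyridin-3-yl on a double-bonded chain carbon bound to a double-bonded ring carbon gives a 1.2-fold higher number from compound 2 to compound 3 (0.07 log units; within the scatter), so compound 2 and compound 3 cannot be ordered against each other. Going by these compounds alone, this is the first measured change at this place, since the earlier step concerned only the group on the amine nitrogen in the ring, and it shows that, with (4-cyanophenyl)sulfonyl on that nitrogen, relocating the ring nitrogen of the pyridine keeps the read-out within the scatter, while the heavy atoms and the counted hydrogen-bond donors and acceptors of the two groups are the same.

As far as these compounds go, what stays open is how pyridin-2-yl, or a plain phenyl ring carrying no ring nitrogen, would read at this same place. From the compounds shown here alone, it is equally open whether the same exchange would stay within the scatter with methyl rather than (4-cyanophenyl)sulfonyl on the amine nitrogen, as this single pair speaks for one substituent there only. No measurement is at hand that would account for this result.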